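Compound 4: adding chloro to a compound at the limit

A few compounds are considered here, and "the series" means these few. Any claim that something is new, unique, unknown or untested is made for them only; others in the source may bear on it.

compound 1 `O=C(Nc1ccc(Oc2ncnc3[nH]ncc23)cc1)Nc1ccc(C(F)(F)F)cc1`: > 10000 nM (a limit)
compound 2 `O=C(Nc1ccc(Oc2ncnc3[nH]ncc23)cc1)Nc1cccnc1`: > 10000 nM (a limit)
compound 3 `O=C(Nc1ccc(Oc2ncnc3[nH]ncc23)cc1)Nc1cccc(F)c1`: > 10000 nM (a limit)

In a functional assay on HeLa cells (Homo sapiens) for inhibition, read by MTT assay, with a stated time of 72 h (a lower number here means a stronger inhibitor, a higher number a weaker inhibitor), compound 1 gives > 10000 nM, which is a limit of the assay and not a number. It therefore has no measured position among the other compounds, and the overall picture is the limit of > 10000 nM in this assay, at which 3 of the 3 values shown sit.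

Compound 4 `O=C(Nc1ccc(Oc2ncnc3[nH]ncc23)cc1)Nc1ccc(C(F)(F)F)cc1Cl` differs from compound 1 by chloro in place of hydrogen on an aromatic carbon.

Three measured changes bear on this one only indirectly, since each exchanges the whole group on an amide-type nitrogen. They are a step that the two limits leave unreadable from compound 1 to compound 2, a step that the two limits leave unreadable from compound 1 to compound 3 and a step that the two limits leave unreadable from compound 2 to compound 3. None gives a size to carry over, and none tests chloro.

In this assay compound 4 is therefore expected to stay near the limit, with no readable direction. The expected step is a step that the limit leaves unreadable from compound 1 to compound 4. The estimated value for compound 4 is 12000 nM, with an expected range from 4000 nM to 30000 nM.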

Compound 4, half-maximal inhibitory concentration: > 10000 nM
Compound 4: a limit, no number; the forecaster's own chance of this, stated with the estimate: 75%; the middle value does not contradict the limit.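

In this assay compound 4 gives > 10000 nM, a limit and not a number. Among the compounds shown here, compound 1 also stands at a limit, so no step between compound 1 and compound 4 can be read. The compounds shown leave open whether chloro or any other change here alters activity, as all share one result: the limit of > 10000 nM in this assay, at which 4 of the 4 values shown sit.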